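The compounds below may be only part of what the source reports. "The series", "measured", "known", "first", "only" and "open" are said of these compounds alone.

Measured so far in a functional assay on Ehrlich cells (Mus musculus) for antiproliferative activity, read by trypan blue exclusion, with a stated time of 2 h, tested at 100 ug/mL; a higher number here means a stronger effect of the compound at the concentration tested, a lower number a weaker effect:
compound 1, `N#CC1=C(N)N(c2ccc(S(N)(=O)=O)cc2)C2=C(C(=O)CCC2)C1c1ccccc1`: 40%
compound 2, `Cc1ccc(C2C(C#N)=C(N)N(c3ccc(S(N)(=O)=O)cc3)C3=C2C(=O)CCC3)cc1`: 100%

Compound 2 stands highest of the two numbers in this assay. Among the compounds with values here, its nearest neighbour is compound 1, and the one measured step, a number 60 percentage points higher from compound 1 to compound 2 (beyond the scatter), is large and beyond the scatter; it rests on methyl in place of hydrogen on an aromatic carbon.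

Compound 3, `N#CC1=C(N)N(c2ccc(S(N)(=O)=O)cc2)C2=C(C(=O)CCC2)C1c1ccc(O)cc1`, is still to be measured. Against compound 2 it differs by hydroxy in place of methyl on an aromatic carbon; cut one bond further out, this reads 4-methylphenyl to 4-hydroxyphenyl.

Within the data shown here, no measured step exchanges methyl for hydroxy, so nothing bears on this change directly. What the series does show is that the same place on the aromatic ring carries the whole of the step of a number 60 percentage points higher from compound 1 to compound 2 (beyond the scatter), so a change there need not be small. Taking the hydroxy analogue as uncertain, compound 3 is expected to lie between the two measured numbers, with the step of a number 35 percentage points lower from compound 2 to compound 3 (beyond the scatter) estimated downward. The estimate for compound 3 is 65%, with a range from 25% to 100%.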

Compound 3, a percentage reported as activity, at one concentration (the size of the read-out at that concentration, not a potency): 100%
Beside the measured number, compound 3's estimate is 35 percentage points below it; the measured number falls inside the stated range.
By their numbers in this assay, from the lowest: compound 1; then compounds 2 and 3 (each within the scatter of the next).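

In this assay, the gain at this place on the aromatic ring, para to a large group, is no longer tied to methyl alone: with hydroxy in place of hydrogen there is a number 60 percentage points higher from compound 1 to compound 3 (beyond the scatter), and this step has the same printed size as the earlier step with methyl. The exchange of methyl for hydroxy brings in a hydrogen-bond donor and a hydrogen-bond acceptor where methyl has neither, and it gives no change at the digits printed from compound 2 to compound 3 (within the scatter), so in this series the read-out does not separate these two groups, and both differ from hydrogen at this place. No measurement at hand accounts for the response to either group.

Only hydrogen, methyl and hydroxy are shown at this place, so it remains open whether an amine, a carboxylic acid, a halogen such as chlorine or a longer chain such as ethoxy would also give a high number or would lose it. From the compounds shown here alone, the read-out comes from one concentration and gives the size of the effect there, so whether compound 2 and compound 3 would also match at other concentrations stays open.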